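The source may report more compounds than this note shows. Statements on the series, on what has been measured and on what is new or still open speak of the compounds shown alone.

Measured so far in an assay for inhibition of Thromboxane-A synthase (Homo sapiens), using microsomes; a higher number here means a weaker inhibitor, a lower number a stronger inhibitor: compound 1 `N#Cc1ccc(C2OCC(C/C=C\CCC(=O)O)C(c3cccnc3)O2)cc1` gives 24 nM; compound 2 `O=C(O)CC/C=C\CC1COC(c2ccc(Cl)cc2Cl)OC1c1cccnc1` gives 42 nM; compound 3 `CC(C)(Oc1ccccc1F)C1OCC(C/C=C\CCC(=O)O)C(c2cccnc2)O1` gives 45 nM.

Compound 3 sits alongside compounds 1 and 2 in this assay; none of the three gaps between them exceeds the scatter. Compound 4 `CC(C)(Oc1ccc(F)cc1[N+](=O)[O-])C1OCC(C/C=C\CCC(=O)O)C(c2cccnc2)O1` differs from compound 3 by 4-fluoro-2-nitrophenyl in place of 2-fluorophenyl on an oxygen on a saturated carbon. Among the compounds with values here, the only measured step, a 1.8-fold higher number from compound 1 to compound 2 (0.24 log units; within the scatter), exchanges an aryl group at another place, on a saturated ring carbon, and stays within the scatter; no measured step touches the aryl group on the oxygen. With that single, unchanged-looking precedent, the change to compound 4 is expected to give no step beyond the scatter, no change at the digits printed from compound 3 to compound 4 (within the scatter). Compound 4 is therefore estimated at 45 nM, in the range 18 nM to 110 nM.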

Compound 4, half-maximal inhibitory concentration: 20 nM
Estimate against measurement, compound 4: 2.3-fold (0.35 log units) above; low and high end bracket the measured number.
By their numbers in this assay, from the lowest: compounds 4, 1, 2 and 3 (each within the scatter of the next, the first and the last beyond it).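

The change to 4-fluoro-2-nitrophenyl on an oxygen on a saturated carbon gives a 2.3-fold lower number from compound 3 to compound 4 (0.35 log units; beyond the scatter) in this assay and is the only step shown beyond the scatter, though a modest one. It shows that this aryl group can shift the number, whereas the earlier step at a saturated ring carbon stayed within the scatter. Nothing given here accounts for the step.

The fluorine changes place and a nitro group enters in the same step, so the compounds shown do not separate the two. On these data alone, whether an amine in place of the nitro group would keep the lower number also remains open.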